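A few compounds are considered here, and "the series" means these few. Any claim that something is new, unique, unknown or untested is made for them only; others in the source may bear on it.

Compound 1 `CC1=C(C(=O)Nc2ccc(F)cc2)C(c2ccc([N+](=O)[O-])cc2)N=C(SCc2ccccc2)N1` gives 38.5% in a functional assay on the whole organism (artery, strain albino) with Rattus norvegicus as the target, with a stated time of 300 min, at a dose of 10 mg/kg by the oral route; a higher number here means more inhibition at the dose given (going by the name of the read-out), a lower number less inhibition. Within the data shown here, compound 2 `CC1=C(C(=O)Nc2ccc(F)cc2)C(c2ccc([N+](=O)[O-])cc2)N=C(SCc2cccc(Cl)c2)N1` gives 18.5% in this assay; the one change between them, (chloro in place of hydrogen on an aromatic carbon), made a step of a number 20 percentage points lower from compound 1 to compound 2 (beyond the scatter). Compound 3 `CC1=C(C(=O)Nc2ccc([N+](=O)[O-])cc2)C(c2ccc(Br)cc2)N=C(SCc2ccccc2)N1` gives 29.7%; the difference between the cores of compound 1 and compound 3 is not broken down here, so their values are simply set side by side. Compound 4 `CC1=C(C(=O)Nc2ccc([N+](=O)[O-])cc2)C(c2ccc(Br)cc2)N=C(SCc2ccccc2Cl)N1` has not yet been measured. It differs from compound 3 by chloro in place of hydrogen on an aromatic carbon. This is the same kind of change as that from compound 1 to compound 2, but not the same: there the chloro sat meta to a large group, here it sits ortho to a large group. Resting on the earlier step, a smaller fall is expected for compound 4, a number 12.7 percentage points lower from compound 3 to compound 4 (beyond the scatter), giving an estimated 17%, between 5% and 32%.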

Compound 4, a percentage reported as inhibition, in the whole organism at one dose (the size of the read-out at that dose, not a potency): 16.9%
Compound 4: middle estimate off by 0.1 percentage points, on the high side; measured number inside the range.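

In this assay, adding chloro to the benzyl ring gave a lower number on both cores, and the new step is a number 12.8 percentage points lower from compound 3 to compound 4 (beyond the scatter). On these two pairs the fall carried over from one core to the other: the same change on two cores in this assay, a number 20 percentage points lower (beyond the scatter) from compound 1 to compound 2 and a number 12.8 percentage points lower (beyond the scatter) from compound 3 to compound 4, 7.2 percentage points apart, within the scatter of two such steps. Among these compounds, this rests on only two pairs, and the chloro stands at a different place on the ring in each, so it neither separates the core from the position nor shows how the change would behave on any other core.

Still open, going by these compounds, is whether the fall holds with the chloro at the same place on both cores. Also open, on these data alone, is whether a methoxy group or an amine on that ring would give a similar fall.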